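Methylamino for methoxy on the benzofuran-bearing core

The source may hold more compounds than are shown below. What is called first, only, known or untested is meant among the compounds shown, and "the series" means these compounds.

Compound 1 `COc1ncnc2c1c(-c1ccccc1)cn2[C@@H]1O[C@H](CO)[C@@H](O)[C@H]1O` and compound 2 `CNc1ncnc2c1c(-c1ccccc1)cn2[C@@H]1O[C@H](CO)[C@@H](O)[C@H]1O` share one core and differ in a single group. In an ADME assay on BJ cells (Homo sapiens), read by MTT assay, with a stated time of 72 h (on this read-out higher numbers stand for weaker inhibition and lower numbers for stronger inhibition), compound 1 gives > 100000 nM, which is a limit of the assay and not a number. Compound 2 gives > 100000 nM, also a limit. The step that the two limits leave unreadable from compound 1 to compound 2 cannot be sized due to the limit of > 100000 nM in this assay, at which 2 of the 3 values shown sit. Among the compounds with values here, compound 3 `COc1ncnc2c1c(-c1cc3ccccc3o1)cn2[C@@H]1O[C@H](CO)[C@@H](O)[C@H]1O` differs from compound 1 by 1-benzofuran-2-yl in place of phenyl on an aromatic carbon; in this assay compound 3 gives 22400 nM, the only number in the set, and the step is an at least 4.4-fold lower number from compound 1 to compound 3 (0.64 log units; beyond the scatter). Compound 4 `CNc1ncnc2c1c(-c1cc3ccccc3o1)cn2[C@@H]1O[C@H](CO)[C@@H](O)[C@H]1O` has not been measured. It differs from compound 3 by methylamino in place of methoxy on an aromatic carbon, the same change as methylamino in place of methoxy on an aromatic carbon on the core of compound 1, made twice among the compounds shown, the two cores differing as stated for compound 3. Because the earlier instance is a step that the two limits leave unreadable from compound 1 to compound 2, no direction is read from it, and the change is expected to leave the number close to that of compound 3, the step from compound 3 to compound 4 being estimated as a 1.5-fold lower number from compound 3 to compound 4 (0.17 log units; within the scatter). Compound 4 is expected at 15000 nM, between 4000 nM and 60000 nM.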

Compound 4, half-maximal inhibitory concentration: 75600 nM
Compound 4: the middle estimate sits 5.0-fold (0.70 log units) below what was measured, outside the stated range (above it).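

In this assay, methylamino in place of methoxy on the core of compound 3 gives a 3.4-fold higher number from compound 3 to compound 4 (0.53 log units; beyond the scatter), so this change has one readable size in the series, on that core only. The same change on the core of compound 1 cannot be read because neither partner gives a number, so nothing shows that the step carries over to that core or that it fails to: the limit of > 100000 nM in this assay, at which 2 of the 4 values shown sit. Read across the other way, 1-benzofuran-2-yl in place of phenyl gives an at least 1.3-fold lower number from compound 2 to compound 4 (0.12 log units; that floor lies within the scatter), and whether that swap has the same size with methoxy and with methylamino stays unsettled: the same change on two cores in this assay, an at least 4.4-fold lower number (0.64 log units; beyond the scatter) from compound 1 to compound 3 and an at least 1.3-fold lower number (0.12 log units; that floor lies within the scatter) from compound 2 to compound 4; the limit leaves it open whether they differ.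

The compounds shown leave open whether the step on the core of compound 3 is particular to methylamino or would recur with an unsubstituted amine, dimethylamino or ethoxy in the same place. They also leave open whether the change keeps its direction on any other core where both partners give numbers rather than limits.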